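The source may hold more compounds than are shown below. What is called first, only, known or untested is meant among the compounds shown, and "the series" means these compounds.

Measured so far:
Compound 1, `O=c1[nH]cc(S(=O)(=O)Nc2ccccc2-c2cn(-c3ccccc3)nn2)c(=O)[nH]1`, in a functional assay on OVCAR-3 cells (Homo sapiens) for antiproliferative activity, read by MTT assay, with a stated time of 24 h (on this read-out lower numbers stand for stronger inhibition and higher numbers for weaker inhibition), gives 6650 nM.
Compound 2, `Cc1ccccc1-n1cc(-c2ccccc2NS(=O)(=O)c2c[nH]c(=O)[nH]c2=O)nn1`, in this assay gives 6550 nM.

For the measured compounds named here, compound 1 stands highest of the two numbers, and compound 2 sits next to it; the only measured step, a 1.0-fold lower number from compound 1 to compound 2 (0.01 log units; within the scatter), is a methyl in place of hydrogen on an aromatic carbon and lies within the scatter, so the two values cannot be ordered.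

Compound 3, `O=c1[nH]cc(S(=O)(=O)Nc2ccccc2-c2cn(-c3cccc(Cl)c3)nn2)c(=O)[nH]1`, has not yet been measured in this assay. It differs from compound 1 by chloro in place of hydrogen on an aromatic carbon, the ring being the six-membered aromatic ring of carbon only, meta to a large group; read one bond further out, phenyl becomes 3-chlorophenyl.

Going by the values given here, the one step that bears on this is the substitution on the same ring, from compound 1 to compound 2, which stayed within the scatter. Among the compounds with values here, no measured step with a chloro exists, so the expectation rests on that single substitution only. A step of about the same size is therefore expected, a 1.1-fold lower number from compound 1 to compound 3 (0.04 log units; within the scatter), that is none beyond the scatter. For compound 3 the expected value in this assay is 6000 nM, with a range from 2500 nM to 14000 nM.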

Compound 3, half-maximal inhibitory concentration: 2180 nM
Compound 3: the middle estimate sits 2.8-fold (0.44 log units) above what was measured, and the stated range ends above it.
By their numbers in this assay, from the lowest: compound 3; then compounds 2 and 1 (each within the scatter of the next).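

In this assay, the phenyl group on the aromatic nitrogen now shows its first step beyond the scatter: chloro in place of hydrogen, meta to a large group, gives a 3.1-fold lower number from compound 1 to compound 3 (0.48 log units; beyond the scatter) and so marks this ring as a place where a single added atom can register. The exchange of 2-methylphenyl for 3-chlorophenyl gives a 3.0-fold lower number from compound 2 to compound 3 (0.48 log units; beyond the scatter) and is of about the same size, whereas methyl in place of hydrogen gives a 1.0-fold lower number from compound 1 to compound 2 (0.01 log units; within the scatter) and stays within the scatter, so on this ring, across these three compounds, a substitution does not by itself move the number. Nothing available on these compounds explains why the chloro step stands out from the methyl step.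

As far as these compounds go, the methyl and chloro groups sit at different places on the ring, so it remains open whether the step belongs to chloro itself or to its place. Also open, from the compounds shown here alone, is how a different kind of group at that place, such as an amine, a methoxy group or a carboxylic acid, would read, and whether a larger step can be reached there at all.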